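Working notes: from compound 3 to compound 4

A few compounds are considered here, and "the series" means these few. Any claim that something is new, unique, unknown or untested is made for them only; others in the source may bear on it.

Compound 1 `O=C(CCCCCCNC(=O)C(O)(O)C(F)(F)F)Nc1nc2ccccc2o1` gives 3450 nM
Compound 2 `COc1ccccc1NC(=O)CCCCCCNC(=O)C(O)(O)C(F)(F)F` gives 10100 nM
Compound 3 `CC(=O)c1ccc(NC(=O)CCCCCCNC(=O)C(O)(O)C(F)(F)F)cc1` gives 12100 nM

In a functional assay on HCT-116 cells (Homo sapiens) for inhibition, read by colorimetric assay, with a stated time of 3 days (on this read-out higher numbers stand for weaker inhibition and lower numbers for stronger inhibition), compound 3 (at 12100 nM) shows a higher number than compound 1 (a 3.5-fold higher number from compound 1 to compound 3 (0.54 log units; beyond the scatter)) and stands level with compound 2 (a 1.2-fold higher number from compound 2 to compound 3 (0.08 log units; within the scatter)). Compound 4 `Cc1ccc(S(=O)(=O)Nc2ccc(NC(=O)CCCCCCNC(=O)C(O)(O)C(F)(F)F)cc2)cc1` carries ((4-methylphenyl)sulfonyl)amino in place of acetyl on an aromatic carbon, para to a large group (((4-methylphenyl)sulfonyl)amino in place of acetyl on an aromatic carbon).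

For the measured compounds named here, no measured step tests this group directly. The nearest evidence is the exchange of groups on the amide-type nitrogen, which stayed modest in compound 2 (a 2.9-fold higher number from compound 1 to compound 2 (0.47 log units; beyond the scatter)) and compound 3 (a 3.5-fold higher number from compound 1 to compound 3 (0.54 log units; beyond the scatter)). As far as these compounds go, no step beyond the scatter is therefore expected in this assay, and the direction stays open. The estimated step (a 1.3-fold lower number from compound 3 to compound 4 (0.13 log units; within the scatter)) is small. Compound 4 is estimated at 9000 nM (expected range 3000 nM to 27000 nM).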

Compound 4, half-maximal inhibitory concentration: 17200 nM
Estimate against measurement, compound 4: 1.9-fold (0.28 log units) below; measured number inside the range.
By their numbers in this assay, from the lowest: compound 1; then compounds 2, 3 and 4 (each within the scatter of the next).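

At this aromatic carbon, para to a large group, ((4-methylphenyl)sulfonyl)amino in place of acetyl gives a 1.4-fold higher number from compound 3 to compound 4 (0.15 log units; within the scatter) in this assay. The earlier compounds shown here varied only the whole group on the amide-type nitrogen, whereas this change adds a six-membered aromatic ring and a hydrogen-bond donor at this carbon with no step beyond the scatter. No measured evidence explains this result.

As far as these compounds go, whether an amine or a carboxylic acid at this carbon would also stay within the scatter of acetyl remains open. So does the effect of a longer chain in the shared core.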